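The source may report more compounds than this note shows. Statements on the series, on what has been measured and on what is new or still open speak of the compounds shown alone.

Measured compounds:
Compound 1, `COC(=O)C=CC(=O)c1sc(Nc2cccc(C)c2)nc1-c1ccncc1`, 2510 nM
Compound 2, `Cc1cccc(Nc2nc(-c3ccncc3-c3ccccc3)cs2)c1`, 11600 nM; 11700 nM (2 entries)

Within the data shown here, in a functional assay on RCC4 cells (Homo sapiens) for inhibition, read by XTT assay, with a stated time of 4 days (on this read-out higher numbers stand for weaker inhibition and lower numbers for stronger inhibition), compound 1 gives 2510 nM, and it is the only compound here with a single number of its own. Compound 2 is recorded with further entries rather than one figure, as shown by the several entries of compound 2 in this assay, 11600 nM; 11700 nM (2 entries), and its values sit well above that of compound 1. Among the measured compounds shown here, no two measured compounds differ from each other in just one place, so no measured step is available.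

Compound 3, `Cc1cccc(Nc2nc(-c3ccncc3)c(CN3CCCCC3)s2)c1`, has not yet been tested in this assay. Compared with compound 1 it differs as follows: (piperidin-1-yl)methyl in place of (2-(methoxycarbonyl)ethenyl)carbonyl on an aromatic carbon. The group that leaves carries three double bonds outside aromatic rings and three hydrogen-bond acceptors, while the entering (piperidin-1-yl)methyl group brings a six-membered non-aromatic ring with one hetero atom and a single acceptor.

Without a measured step to lean on, compound 3 is expected to sit weaker than compound 1 by a step of a 3.2-fold higher number from compound 1 to compound 3 (0.50 log units; beyond the scatter), beyond the usual scatter. The estimate for compound 3 is 8000 nM, between 2500 nM and 25000 nM.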

Compound 3, half-maximal inhibitory concentration: 13200 nM
Compound 3: middle estimate off by 1.7-fold (0.22 log units), on the low side, and the stated range covers the measured number.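

Among these compounds, the first measured step in this set falls on the aromatic carbon next to the ring sulfur, and in this assay it reads a 5.3-fold higher number from compound 1 to compound 3 (0.72 log units; beyond the scatter), with (piperidin-1-yl)methyl in place of (2-(methoxycarbonyl)ethenyl)carbonyl. This shows that the position is not indifferent to what it carries: with the rest of compound 1 unchanged, exchanging this open chain for the ring-bearing (piperidin-1-yl)methyl group goes with weaker inhibition, by more than the usual scatter. Nothing measured here bears on why the change has this effect.

The step replaces the whole group at once, so it cannot separate the contribution of the carbonyl next to the aromatic ring from that of the ethenyl link or the methoxycarbonyl end. As far as these compounds go, whether a carboxylic acid or a simple amide at the chain end would keep the value nearer that of compound 1, and whether a morpholine ring or an open-chain amine such as dimethylaminomethyl would read like the (piperidin-1-yl)methyl group of compound 3, remains open.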